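Chloro for hydrogen on the anilino ring of compound 2

This account rests on a few compounds, and the source may have more. Where it says the series, first, only, none or still open, it means among the compounds named here.

For the measured compounds named here, compound 2 `Cc1nc(Nc2ccccc2)sc1C(=O)/C=C/c1ccccc1` gives 19500 nM in a functional assay on BGC-823 cells (Homo sapiens) for cytotoxicity, read by MTT assay (on this read-out higher numbers stand for weaker inhibition and lower numbers for stronger inhibition), and is the only compound here with a number rather than a limit. Compound 1 `Cc1ccc(Nc2nc(C)c(C(=O)/C=C/c3ccccc3)s2)cc1` reports only a limit in this assay, > 25000 nM, which is the limit of > 25000 nM in this assay, at which 1 of the 2 values shown sits. Going by the values given here, the single measured step, an at least 1.2-fold lower number from compound 1 to compound 2 (0.10 log units; that floor lies within the scatter), concerns hydrogen in place of methyl on an aromatic carbon and has a floor within the scatter. Compound 3 `Cc1nc(Nc2cccc(Cl)c2)sc1C(=O)/C=C/c1ccccc1` differs from compound 2 by chloro in place of hydrogen on an aromatic carbon. Among the compounds with values here, no measured step covers an entering chloro, so the expected step in this assay is a 1.3-fold lower number from compound 2 to compound 3 (0.11 log units; within the scatter), not beyond the scatter. Compound 3 is estimated at 15000 nM, between 6000 nM and 40000 nM.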

Compound 3, half-maximal inhibitory concentration: > 25000 nM
Compound 3: a limit, no number (the forecaster's own chance of this, stated with the estimate: 25%); at least 1.6-fold (0.22 log units) between middle value and limit.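

In this assay chloro in place of hydrogen on the anilino ring, meta to a large group, gives an at least 1.2-fold higher number from compound 2 to compound 3 (0.10 log units; that floor lies within the scatter) and no sign of stronger inhibition. Going by these compounds, compound 3 reports a limit and no number, so its true distance from compound 2 stays unknown: the limit of > 25000 nM in this assay, at which 2 of the 3 values shown sit. The step between the two limits, from compound 1 to compound 3, cannot be read.

Open, on these data alone, is how far compound 3 lies past its limit. Also open, as far as these compounds go, is whether an amine or a carboxylic acid on this ring would bring a readable number.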